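The source may hold more compounds than are shown below. What is called first, only, known or untested is meant among the compounds shown, and "the series" means these compounds.

Compound 1, `O=C(c1ccccc1)N1N=C(c2cc3ccccc3oc2=O)CC1c1ccccc1`: in a functional assay on PC-3 cells (Homo sapiens) for cytotoxicity, read by MTT assay, with a stated time of 48 h (on this read-out higher numbers stand for weaker inhibition and lower numbers for stronger inhibition), compound 1 gives 5870 nM.
Compound 2, `Cc1ccc(C(=O)N2N=C(c3cc4ccccc4oc3=O)CC2c2ccccc2)cc1`: in this assay compound 2 gives 13200 nM.
Compound 3, `CCC(=O)N1N=C(c2cc3ccccc3oc2=O)CC1c1ccccc1`: in this assay compound 3 gives 4370 nM.

Compound 3 has the lowest number of the three, yet its gap to compound 1 is within the scatter, so it cannot be called the most potent; only its gap to compound 2 is beyond it.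

Compound 4, `O=C(CCl)N1N=C(c2cc3ccccc3oc2=O)CC1c1ccccc1`, differs from compound 3 in one place: chloro in place of methyl on a saturated chain carbon bound to a carbonyl carbon. Here, on the carbonyl substituent, the measured steps were a 1.3-fold lower number from compound 1 to compound 3 (0.13 log units; within the scatter) and a 3.0-fold lower number from compound 2 to compound 3 (0.48 log units; beyond the scatter). Among the compounds with values here, they swap large aryl groups for ethyl on the carbonyl carbon; none of them exchanges a methyl for a chloro on a saturated chain carbon, so there is no direct precedent. Since these steps stayed small or modest, the expectation is a step of a 1.1-fold lower number from compound 3 to compound 4 (0.04 log units; within the scatter), that is, none beyond the scatter in either direction. Compound 4 is therefore estimated at 4000 nM, expected between 1500 nM and 12000 nM.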

Compound 4, half-maximal inhibitory concentration: 2980 nM
Beside the measured number, compound 4's estimate is 1.3-fold (0.13 log units) above it; the measured number falls inside the stated range.
By their numbers in this assay, from the lowest: compounds 4, 3 and 1 (each within the scatter of the next); then compound 2.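

In this assay, chloro in place of methyl on a saturated chain carbon bound to a carbonyl carbon gives a 1.5-fold lower number from compound 3 to compound 4 (0.17 log units; within the scatter), so this exchange at the end of the short chain shifts the number by no more than the scatter. Chloromethyl in place of phenyl on the carbonyl carbon gives a 2.0-fold lower number from compound 1 to compound 4 (0.29 log units; within the scatter), which is also within the scatter, whereas chloromethyl in place of 4-methylphenyl gives a 4.4-fold lower number from compound 2 to compound 4 (0.65 log units; beyond the scatter), so compound 2 alone stands apart from the other three. Nothing given here accounts for these steps.

The compounds shown leave open whether an amine, a hydroxyl or a bromo on the same chain carbon would behave as chloro does. They also leave open what a longer chain carrying the chloro would give.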